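Swapping hydroxy for amino on a quinoline-type inhibitor series

A few compounds are considered here, and "the series" means these few. Any claim that something is new, unique, unknown or untested is made for them only; others in the source may bear on it.

The measured compounds and their values:
- compound 1 `COc1cc(OC)cc(-c2cc3ccccc3c(-c3cccc(N)c3)n2)c1` gives 0% in an assay on isolated protein for inhibition of DNA topoisomerase 1 (Homo sapiens), with a stated time of 30 min, tested at 100 uM; on this read-out lower numbers stand for a weaker effect and higher numbers for a stronger effect at the one concentration tested
- compound 2 `COc1ccc(-c2cc3cc(C)ccc3c(-c3cccc(O)c3)n2)cc1OC` gives 1.7% in this assay

Both numbers sit close to zero, and the gap between compound 1 and compound 2 lies within the usual scatter of this kind of measurement. Compound 2 therefore cannot be called more active than compound 1; the two values simply show that neither compound does much in this assay at the single concentration tested.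

Compound 3 `COc1ccc(-c2cc3cc(C)ccc3c(-c3cccc(N)c3)n2)cc1OC` differs from compound 2 in one place: amino in place of hydroxy on an aromatic carbon. The change sits on the phenyl ring meta to a large group, and compound 1 already carries the same 3-aminophenyl group on a closely related core. Within the data shown here, no step between measured compounds is available here, so the expectation rests on the two values alone. Because compound 1 gives 0% with the amino group in place, little movement is expected, and the step from compound 2 to compound 3 is estimated as a number 0.7 percentage points lower from compound 2 to compound 3 (within the scatter), not beyond the scatter in either direction. Compound 3 is expected to give 1% in this assay, with a range from 0% to 8%.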

Compound 3, a percentage reported as inhibition, at one concentration (the size of the read-out at that concentration, not a potency): 7.2%
For compound 3 the middle estimate is 6.2 percentage points below the measured one, within the range that was stated.
By their numbers in this assay, from the lowest: compounds 1, 2 and 3 (each within the scatter of the next).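

Going from 3-hydroxyphenyl to 3-aminophenyl on an otherwise identical structure gives a number 5.5 percentage points higher from compound 2 to compound 3 (within the scatter) in this assay. Among these compounds, this is the first comparison that isolates this position, since compound 1 and compound 2 differ in more than one place and could say nothing about the exchange of hydroxy for amino alone; with only this one place changed, the two groups still cannot be told apart at the single concentration tested. Nothing available explains the result or bears on it from another measurement.

Going by these compounds, what a methoxy group, a carboxylic acid or an aminomethyl group at this place would give remains open, as does whether any group here can move the read-out beyond the scatter. Also open, on these data alone, is whether exchanging amino for hydroxy would read the same way on the core of compound 1, and how these compounds behave at other concentrations, since a result at one concentration gives the size of an effect and not a potency.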